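Changing the aryl group on the amide of compound 3

The compounds below may be only part of what the source reports. "The series", "measured", "known", "first", "only" and "open" are said of these compounds alone.

- compound 1 `O=C(CN1CCN(c2nnc(Cc3ccccc3)c3ccccc23)CC1)Nc1c(F)cccc1F` with 84500 nM
- compound 2 `O=C(CN1CCN(c2nnc(Cc3ccccc3)c3ccccc23)CC1)Nc1ccc(F)c(C(F)(F)F)c1` with 2480 nM
- compound 3 `Cc1ccc(F)cc1NC(=O)CN1CCN(c2nnc(Cc3ccccc3)c3ccccc23)CC1` with "not active" (no number reported)

These results come from a functional assay on A549 cells (Homo sapiens) for cytotoxicity, read by MTT assay, with a stated time of 72 h (a lower number here means a stronger inhibitor, a higher number a weaker inhibitor), and compound 3 has no number there. Compound 4 `COc1ccc(NC(=O)CN2CCN(c3nnc(Cc4ccccc4)c4ccccc34)CC2)cc1OC` differs from compound 3 on an amide-type nitrogen: 3,4-dimethoxyphenyl in place of 5-fluoro-2-methylphenyl on an amide-type nitrogen. Among the measured compounds shown here, the only measured step, a 34-fold lower number from compound 1 to compound 2 (1.53 log units; beyond the scatter), changes the group at that same place and is large, so a change here can matter. It involves different groups, however, and compound 3 offers no number to step from, so no step size can be set. With compound 3 at "not active" (no number reported), a weak result is expected, closer to compound 1 (84500 nM) than to compound 2 (2480 nM). The estimate for compound 4 is 30000 nM, with an expected range from 6000 nM to 100000 nM.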

Compound 4, half-maximal inhibitory concentration: "not active" (no number reported)
Nothing numeric was reported for compound 4; no gap can be computed for the estimate.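

Compound 3 and compound 4 are both reported as "not active" in this assay, without a number, so no step can be read between them. Going by these compounds, how far 3,4-dimethoxyphenyl and 5-fluoro-2-methylphenyl differ in effect stays open. Nothing shown here bears on the reason for this result.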